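Notes on the aromatic-nitrogen substituent in this series

A few compounds are considered here, and "the series" means these few. Any claim that something is new, unique, unknown or untested is made for them only; others in the source may bear on it.

Among the measured compounds shown here, compound 3 `CNC(=O)Nc1ccc(-c2nc(N3CC4CCC(C3)O4)c3cnn([C@H]4CC[C@@H](O)CC4)c3n2)cc1` gives 20 nM in a functional assay on LNCaP cells (Homo sapiens) for cytotoxicity (a lower number here means a stronger inhibitor, a higher number a weaker inhibitor), the second highest of the three numbers so far. Compound 2 `CNC(=O)Nc1ccc(-c2nc(N3CC4CCC(C3)O4)c3cnn(C(C)C)c3n2)cc1` gives 5 nM, and compound 1 `CCn1ncc2c(N3CC4CCC(C3)O4)nc(-c3ccc(NC(=O)NC)cc3)nc21` gives 70 nM. Every measured step alters the group on the aromatic nitrogen: a 14-fold lower number from compound 1 to compound 2 (1.15 log units; beyond the scatter), a 3.5-fold lower number from compound 1 to compound 3 (0.54 log units; beyond the scatter), and a 4.0-fold higher number from compound 2 to compound 3 (0.60 log units; beyond the scatter). Compound 4 `CNC(=O)Nc1ccc(-c2nc(N3CC4CCC(C3)O4)c3cnn(CCO)c3n2)cc1` remains to be measured. It differs from compound 3 thus: 2-hydroxyethyl in place of 4-hydroxycyclohexyl on an aromatic nitrogen. The 2-hydroxyethyl chain is nearer in size to the ethyl of compound 1 than to the 4-hydroxycyclohexyl of compound 3, so the step from compound 1 to compound 3 is the most relevant of the measured steps, and compound 4 should sit between compound 1 and compound 3. For compound 4 the expected change is a 2.0-fold higher number from compound 3 to compound 4 (0.30 log units; within the scatter), a modest rise in number, because compound 1 carrying ethyl gives 70 nM. Compound 4 is therefore estimated at 40 nM, with a range from 15 nM to 120 nM.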

Compound 4, half-maximal inhibitory concentration: 650 nM
For compound 4 the middle estimate is 16-fold (1.21 log units) below the measured one; the whole stated range lies below it.
By their numbers in this assay, from the lowest: compound 2; then compound 3; then compound 1; then compound 4.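

Hydroxy on the ethyl chain raises the number, a 9.3-fold higher number from compound 1 to compound 4 (0.97 log units; beyond the scatter), so this position does not accept that addition without a loss. The 4-hydroxycyclohexyl and 2-hydroxyethyl groups have the same counts of hydrogen-bond donors and acceptors, yet the exchange gives a 33-fold higher number from compound 3 to compound 4 (1.51 log units; beyond the scatter), which shows that these counts alone do not set the number here. The span across this position also widens, with a 130-fold higher number from compound 2 to compound 4 (2.11 log units; beyond the scatter) separating isopropyl and 2-hydroxyethyl, the lowest and highest of the four compounds.

No measurement shown explains these differences. Still open, going by these compounds, is whether the rise follows the free hydroxy or the short chain, a question that a 2-methoxyethyl group or a longer chain such as 3-hydroxypropyl on the same aromatic nitrogen could help to settle.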